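Methylating the pyrrole nitrogen of compound 1

The source may hold more compounds than are shown below. What is called first, only, known or untested is meant among the compounds shown, and "the series" means these compounds.

Compound 1 `Cc1cc(=O)n(-c2ccc(Br)cc2F)nc1C(=O)Nc1ccc(Oc2ncnc3[nH]ccc23)cc1` gives 3660 nM in a functional assay on HepG2 cells (Homo sapiens) for cytotoxicity, read by MTT assay, with a stated time of 72 h (on this read-out lower numbers stand for stronger inhibition and higher numbers for weaker inhibition), the lowest of the two numbers measured. Going by the values given here, compound 2 `Cc1cc(=O)n(-c2cccc(C(F)(F)F)c2)nc1C(=O)Nc1ccc(Oc2ncnc3[nH]ccc23)cc1`, with a different aryl group on the pyrazolone nitrogen, gives 9470 nM, and the step of a 2.6-fold higher number from compound 1 to compound 2 (0.41 log units; beyond the scatter) concerns only that aryl group. Compound 3 `Cc1cc(=O)n(-c2ccc(Br)cc2F)nc1C(=O)Nc1ccc(Oc2ncnc3c2ccn3C)cc1` differs from compound 1 by methyl in place of hydrogen on an aromatic nitrogen. Among the compounds with values here, no measured step touches this position, so nothing here tells how large a change to expect. A small loss of potency is nonetheless expected, giving a step of a 1.8-fold higher number from compound 1 to compound 3 (0.25 log units; within the scatter). Compound 3 is therefore estimated at 6500 nM, within 2500 nM to 17000 nM.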

Compound 3, half-maximal inhibitory concentration: 33600 nM
Compound 3: the middle estimate sits 5.2-fold (0.71 log units) below what was measured, outside the stated range (above it).
By their numbers in this assay, from the lowest: compound 1; then compound 2; then compound 3.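

This aromatic nitrogen of the five-membered ring proves sensitive in this assay: methyl in place of hydrogen gives a 9.2-fold higher number from compound 1 to compound 3 (0.96 log units; beyond the scatter). So the smallest carbon group, a single added heavy atom, is enough to weaken the read-out beyond the usual scatter. No measurement at hand explains this loss. On these data alone, whether an ethyl group or a chain ending in an amine on this nitrogen would raise the number further remains open. So does whether methyl here has a similar effect alongside the 3-(trifluoromethyl)phenyl group of compound 2.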